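Catechol vinyl sulfones: varying the chain on the sulfonyl sulfur

This account rests on a few compounds, and the source may have more. Where it says the series, first, only, none or still open, it means among the compounds named here.

Measured so far in a functional assay, read by fluorescence and spectrophotometry, with a stated time of 1 h; a lower number here means that less compound is needed, a higher number that more compound is needed for the effect:
compound 1 `C=CCCCCCS(=O)(=O)/C=C/c1ccc(O)c(O)c1`: 7100 nM
compound 2 `O=S(=O)(/C=C/c1ccc(O)c(O)c1)CCCc1ccccc1`: 11500 nM
compound 3 `C=CCCCCCCCS(=O)(=O)/C=C/c1ccc(O)c(O)c1`: 6900 nM

Compound 1 sits among three values that all fall within the scatter of one another: the step of a 1.0-fold lower number from compound 1 to compound 3 (0.01 log units; within the scatter) and the step of a 1.6-fold higher number from compound 1 to compound 2 (0.21 log units; within the scatter) both leave the shared core unaffected by what hangs on the sulfonyl chain. Compound 4 `O=S(=O)(/C=C/c1ccc(O)c(O)c1)CC1CC1` has not yet been measured; it differs from compound 1 as follows: cyclopropyl in place of hex-5-en-1-yl on a saturated chain carbon bound to a sulfonyl sulfur.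

The three measured steps of a 1.6-fold higher number from compound 1 to compound 2 (0.21 log units; within the scatter), a 1.0-fold lower number from compound 1 to compound 3 (0.01 log units; within the scatter) and a 1.7-fold lower number from compound 2 to compound 3 (0.22 log units; within the scatter) all alter this same chain and all stay within the scatter, so no step beyond the scatter is expected here either. Compound 4 is therefore expected at about 7500 nM in this assay, with a range of 3200 nM to 17000 nM, which means an estimated step of a 1.1-fold higher number from compound 1 to compound 4 (0.02 log units; within the scatter).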

Compound 4, half-maximal effective concentration: 10500 nM
Compound 4: the middle estimate sits 1.4-fold (0.15 log units) below what was measured; low and high end bracket the measured number.
By their numbers in this assay, from the lowest: compounds 3, 1, 4 and 2 (each within the scatter of the next).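

In this assay, cyclopropyl in place of hex-5-en-1-yl on a saturated chain carbon bound to a sulfonyl sulfur gives a 1.5-fold higher number from compound 1 to compound 4 (0.17 log units; within the scatter). A group of 3 heavy atoms with a three-membered ring and no double bond, replacing one of 6 heavy atoms, therefore stays within the scatter, as the chains of compound 2 and compound 3 did. No supporting measurement bears on this result. The groups shown at this position contain only carbon. As far as these compounds go, whether an amine or a carboxylic acid on this chain would give a step beyond the scatter remains open.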